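Hydroxyl substitution on the hydrazone aryl ring and cytotoxicity

The source may hold more compounds than are shown below. What is called first, only, known or untested is meant among the compounds shown, and "the series" means these compounds.

Compound 1 `COc1ccccc1-c1nnc(-c2ccc(C(=O)N/N=C/c3ccc(F)cc3)cc2)o1`: 427000 nM
Compound 2 `COc1ccccc1-c1nnc(-c2ccc(C(=O)N/N=C/c3ccccc3O)cc2)o1`: 207000 nM
Compound 3 `COc1ccccc1-c1nnc(-c2ccc(C(=O)N/N=C/c3ccccc3F)cc2)o1`: 313000 nM

These three compounds share one core and differ only in the aryl ring on the carbon with a double bond to nitrogen. In an ADME assay on THP-1 cells (Homo sapiens) for cytotoxicity (on this read-out higher numbers stand for weaker inhibition and lower numbers for stronger inhibition), compound 3 stands second highest of the three numbers, near compound 1 and somewhat further from compound 2, with both gaps within the scatter. Compound 4 `COc1ccccc1-c1nnc(-c2ccc(C(=O)N/N=C/c3ccc(O)cc3O)cc2)o1` is the next member: 2,4-dihydroxyphenyl in place of 2-fluorophenyl on a carbon with a double bond to nitrogen. Among the measured compounds shown here, two measured steps bear on this change. Swapping hydroxy for fluoro on the aromatic carbon gave a 1.5-fold higher number from compound 2 to compound 3 (0.18 log units; within the scatter), and moving from the 4-fluorophenyl of compound 1 to the 2-hydroxyphenyl of compound 2 gave a 2.1-fold lower number from compound 1 to compound 2 (0.31 log units; beyond the scatter). Since the entering ring carries a hydroxy where compound 2 does, plus a second one, compound 4 is expected to land slightly lower, with a 1.6-fold lower number from compound 3 to compound 4 (0.19 log units; within the scatter) barely beyond or within the scatter. Compound 4 is thus estimated at 200000 nM, in a range from 100000 nM to 400000 nM.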

Compound 4, half-maximal inhibitory concentration: 104000 nM
Compound 4: middle estimate off by 1.9-fold (0.28 log units), on the high side, within the range that was stated.
By their numbers in this assay, from the lowest: compounds 4, 2, 3 and 1 (each within the scatter of the next, the first and the last beyond it).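

In this assay, the 2,4-dihydroxyphenyl ring on the carbon with a double bond to nitrogen stands clearly apart from both fluorinated rings (a 3.0-fold lower number from compound 3 to compound 4 (0.48 log units; beyond the scatter), and a 4.1-fold lower number from compound 1 to compound 4 (0.61 log units; beyond the scatter)), whereas the earlier comparison of 2-hydroxyphenyl with 2-fluorophenyl did not reach that separation. The added hydroxy on its own does not separate the two hydroxylated compounds (a 2.0-fold lower number from compound 2 to compound 4 (0.30 log units; within the scatter)), so these two cannot be ordered, yet only the 2,4-dihydroxyphenyl ring is parted from both fluorophenyl rings. Nothing available explains these differences.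

On these data alone, whether a methoxy, an amine or a carboxylic acid in place of the hydroxy groups would give numbers like these remains open. So does whether a pyridine in place of the phenyl ring would keep them.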